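Swapping the nitrile for a chlorine on the benzamide ring

The compounds below may be only part of what the source reports. "The series", "measured", "known", "first", "only" and "open" are said of these compounds alone.

Of the compounds shown here, three sharing one core have been measured in a functional assay on HEK293 cells for agonist activity at probable G-protein coupled receptor 27 (Homo sapiens), read by a luciferase reporter and beta-arrestin recruitment, with a stated time of 10 min; on this read-out higher numbers stand for an effect only at larger amounts of compound and lower numbers for an effect already at smaller amounts. Compound 1 `O=C(Nc1ccc(S(=O)(=O)Nc2ccccc2)cc1)c1ccc(Cl)nc1F` gives 2290 nM. Compound 2 `O=C(Nc1ccc(S(=O)(=O)Nc2ccccc2)cc1)c1ccc(Br)cc1F` gives 479 nM. Compound 3 `N#Cc1ccc(C(=O)Nc2ccc(S(=O)(=O)Nc3ccccc3)cc2)c(F)c1` gives 229 nM, the lowest of the three numbers, and both its steps to the others are beyond the scatter: a 10-fold lower number from compound 1 to compound 3 (1.00 log units; beyond the scatter) and a 2.1-fold lower number from compound 2 to compound 3 (0.32 log units; beyond the scatter). The remaining step, a 4.8-fold lower number from compound 1 to compound 2 (0.68 log units; beyond the scatter), separates the two halogen-bearing benzamides from each other.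

Compound 4 `O=C(Nc1ccc(S(=O)(=O)Nc2ccccc2)cc1)c1cc(F)c(Cl)cc1F` has not yet been tested. Its change from compound 3 is 4-chloro-2,5-difluorophenyl in place of 4-cyano-2-fluorophenyl on a carbonyl carbon. The step that bears on it most directly is a 2.1-fold lower number from compound 2 to compound 3 (0.32 log units; beyond the scatter), which shows that exchanging a halogen for the cyano group lowered the number. Among the measured compounds shown here, compound 4 reverses that exchange, placing a chloro where compound 3 carries the cyano, and adds a second fluorine, for which no measured step exists. A modest rise back toward the number of compound 2 is therefore expected, as a 2.6-fold higher number from compound 3 to compound 4 (0.42 log units; beyond the scatter). Compound 4 is estimated at 600 nM, within a range from 200 nM to 2000 nM.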

Compound 4, half-maximal effective concentration: 141 nM
Estimate against measurement, compound 4: 4.3-fold (0.63 log units) above; the whole stated range lies above it.
By their numbers in this assay, from the lowest: compounds 4 and 3 (each within the scatter of the next); then compound 2; then compound 1.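

In this assay, 4-chloro-2,5-difluorophenyl in place of 4-cyano-2-fluorophenyl gives a 1.6-fold lower number from compound 3 to compound 4 (0.21 log units; within the scatter) and so shows that, on this carbonyl carbon, a ring without the nitrile can stay level with the nitrile-bearing ring of compound 3. The same group also separates compound 4 from the other two halogen-bearing rings, with a 3.4-fold lower number from compound 2 to compound 4 (0.53 log units; beyond the scatter) and with a 16-fold lower number from compound 1 to compound 4 (1.21 log units; beyond the scatter) as the larger step, so a halogen in place of the nitrile does not by itself raise the number, although compound 2 and compound 1 both stand above compound 3. Nothing measured here offers an explanation for these differences.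

The chloro and the second fluorine enter together, so the compounds shown do not separate what each contributes. They also leave open how a ring carrying a trifluoromethyl, a methoxy or an amine in place of the chloro would read in this assay on this core.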